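Nitroimidazole carboxamide series: para substituent swap on the benzyl

The compounds below may be only part of what the source reports. "The series", "measured", "known", "first", "only" and "open" are said of these compounds alone.

Compound 1 is `NC(=O)c1ncc([N+](=O)[O-])[nH]1`. In a toxicity assay on HepG2 cells (Homo sapiens) for inhibition, read by resazurin assay, with a stated time of 24 h (a lower number here means that less compound is tolerated, a higher number that more compound is tolerated), compound 1 gives > 100000 nM, which is a limit of the assay and not a number. Compound 2, `NC(=O)c1nc([N+](=O)[O-])cn1Cc1ccc(F)cc1`, carries a benzyl group on the core of compound 1. In this assay compound 2 gives > 100000 nM, again a limit of the assay rather than a number. Within the data shown here, compound 2 therefore stands at the ceiling of the measured range, and the only other value shown, that of compound 1, sits at the same limit (the limit of > 100000 nM in this assay, at which 2 of the 2 values shown sit). Among the measured compounds shown here, no step between measured compounds is available in this assay.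

Compound 3 is `NC(=O)c1nc([N+](=O)[O-])cn1Cc1ccc(OC(F)(F)F)cc1`. It differs from compound 2 as follows: trifluoromethoxy in place of fluoro on an aromatic carbon. With both known values sitting at the limit, no step beyond the scatter is expected from compound 2 to compound 3 in this assay, and a step that the limit leaves unreadable from compound 2 to compound 3 is the estimated step. Compound 3 is expected to give about 150000 nM in this assay, within the range 60000 nM to 400000 nM, most probably reported as a limit again.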

Compound 3, half-maximal cytotoxic concentration: > 100000 nM
Compound 3 was reported as a limit; the forecaster's own chance of this, stated with the estimate: 75%; the middle value is on the limit's open side.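

No step can be read between compound 2 and compound 3 in this assay because both values are limits of the assay and not numbers: the limit of > 100000 nM in this assay, at which 3 of the 3 values shown sit.

The compounds shown leave open where the half-maximal cytotoxic concentration of any of them actually lies, and whether any para substituent would bring a value inside the measured range.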